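Swapping chlorine for fluorine on the sulfonyl-linked ring

A few compounds are considered here, and "the series" means these few. Any claim that something is new, unique, unknown or untested is made for them only; others in the source may bear on it.

Measured compounds:
compound 1 `CN1CCC(c2n[nH]c3ccc(S(=O)(=O)c4cccc(Cl)c4)cc23)CC1`: 19 nM
compound 2 `CN1CCC(c2n[nH]c3ccc(S(=O)(=O)c4ccc(F)cc4)cc23)CC1`: 66 nM

Among the measured compounds shown here, in an assay on HeLa cells for displacement of a labelled ligand from 5-hydroxytryptamine receptor 6 (Homo sapiens) (on this read-out higher numbers stand for weaker inhibition and lower numbers for stronger inhibition), compound 1 gives 19 nM, the lowest of the two numbers measured so far. For the measured compounds named here, compound 2 gives 66 nM, and the step of a 3.5-fold higher number from compound 1 to compound 2 (0.54 log units; beyond the scatter) is the only measured comparison available here.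

Compound 3 `CN1CCC(c2n[nH]c3ccc(S(=O)(=O)c4cccc(F)c4)cc23)CC1` differs from compound 1 by fluoro in place of chloro on an aromatic carbon. Cut one bond further out, this reads as 3-chlorophenyl to 3-fluorophenyl, so the ring keeps its substituent in the same named position and only the halogen changes. Going by the values given here, the one measured step bears on it only partly: going from compound 1 to compound 2 changed both the halogen and the position in the group's name, and the number rose modestly. Since compound 3 carries only the halogen part of that change, a smaller rise is expected, around the edge of the usual scatter and probably not beyond the modest step to compound 2. Compound 3 is therefore estimated at 40 nM in this assay, in the range 15 nM to 100 nM. This expected step, a 2.1-fold higher number from compound 1 to compound 3 (0.32 log units; beyond the scatter), is a small weakening.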

Compound 3, inhibition constant: 93 nM
Compound 3: middle estimate off by 2.3-fold (0.37 log units), on the low side; measured number inside the range.
By their numbers in this assay, from the lowest: compound 1; then compounds 2 and 3 (each within the scatter of the next).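

With the named position held fixed, the halogen alone makes a clear difference in this assay: fluoro in place of chloro gives (a 4.9-fold higher number from compound 1 to compound 3 (0.69 log units; beyond the scatter)), a step beyond the usual scatter. Moving the fluoro gives (a 1.4-fold higher number from compound 2 to compound 3 (0.15 log units; within the scatter)), which lies within the scatter, so these two fluoro compounds do not separate the two ring positions, and the higher number of compound 2 relative to compound 1 no longer needs a change of position to account for it. Compound 1 remains the strongest of the three, but no measurement offered here explains why the chloro compound gives the lowest number.

The halogen comparison rests on a single pair of compounds, so it shows what happens on going from chloro to fluoro at this one position and is not a general rule for the series. A bromo, methyl or methoxy group on the same ring, or a plain phenyl with no substituent at all, would test whether compound 1 owes its number to chloro specifically or whether other groups serve equally well.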